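The source may report more compounds than this note shows. Statements on the series, on what has been measured and on what is new or still open speak of the compounds shown alone.

Compound 1 `COc1ccc(C2C(O)C(=O)N2c2cc(OC)c(OC)c(OC)c2)cc1`: 12 nM
Compound 2 `CCOc1ccc(C2C(Oc3ccccc3)C(=O)N2c2cc(OC)c(OC)c(OC)c2)cc1`: 388 nM
Compound 3 `COc1ccc(C2CC(=O)N2c2cc(OC)c(OC)c(OC)c2)cc1`: 65 nM

These three compounds were tested in a functional assay on HT-29 cells (Homo sapiens) for inhibition, read by sulforhodamine B assay, with a stated time of 72 h; a lower number here means a stronger inhibitor, a higher number a weaker inhibitor. Compound 1 has the lowest number of the three, and so stands as the strongest inhibitor in the set. Compound 3 is its nearest neighbour, and compound 2 lies furthest away, at 388 nM.

The next compound, compound 4 `COc1cc(N2C(=O)C(O)C2c2ccc(SC)cc2)cc(OC)c1OC`, keeps the core of compound 1 and carries methylsulfanyl in place of methoxy on an aromatic carbon, para to a large group: methylsulfanyl in place of methoxy on an aromatic carbon.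

Within the data shown here, no measured step touches that position alone. Among the measured compounds shown here, the only single-place step available is a 5.4-fold higher number from compound 1 to compound 3 (0.73 log units; beyond the scatter), which puts hydrogen in place of hydroxy on a saturated ring carbon. For the measured compounds named here, it is a different change at a different place, and it shows only that one change in this set can move the number modestly. Compound 2 differs from compound 1 in more than one place, so its value cannot be assigned to any single change.

With so little direct evidence, only a small step is expected in this assay, leaning towards a higher number. The expected change is a 1.7-fold higher number from compound 1 to compound 4 (0.22 log units; within the scatter). Compound 4 is estimated at 20 nM, with an expected range of 5 nM to 90 nM.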

Compound 4, half-maximal inhibitory concentration: 15 nM
The estimate for compound 4 lay 1.3-fold (0.12 log units) above the measured number, within the range that was stated.
By their numbers in this assay, from the lowest: compounds 1 and 4 (each within the scatter of the next); then compound 3; then compound 2.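

In this assay, methylsulfanyl in place of methoxy on an aromatic carbon, para to a large group, gives a 1.3-fold higher number from compound 1 to compound 4 (0.10 log units; within the scatter), so compound 4 cannot be told apart from compound 1 by this number. Among these compounds, this is the first single-place reading at this position, which the earlier compounds did not provide, and it shows that this exchange of one two-atom group for another leaves the number within the scatter while the rest of the core of compound 1 stays the same. The data shown offer no measurement that could explain this result.

What the compounds shown leave open is how far this tolerance extends, since a single exchange says nothing about an amine, a chlorine atom or a longer chain such as propoxy at the same position. They also leave open whether the 4-methoxyphenyl to 4-(methylsulfanyl)phenyl exchange would read the same on the core of compound 3, which lacks the hydroxy group, for no compound shown carries methylsulfanyl there.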